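Anilide variation and mouse microsomal clearance in the series

This account rests on a few compounds, and the source may have more. Where it says the series, first, only, none or still open, it means among the compounds named here.

Measured so far:
compound 1, `CN1C[C@H](C(=O)Nc2ccc(F)cc2)[C@@H](c2ccc(/C=C/C(=O)Nc3ccccc3N)cc2)C1`: 34 mL/min/kg
compound 2, `COc1ccc(NC(=O)[C@H]2CN(C)C[C@@H]2c2ccc(/C=C/C(=O)Nc3ccccc3N)cc2)cc1`: 54 mL/min/kg
compound 3, `CN1C[C@H](C(=O)Nc2cccc(Cl)c2)[C@@H](c2ccc(/C=C/C(=O)Nc3ccccc3N)cc2)C1`: 58 mL/min/kg

All three numbers come from an in vitro ADME assay on microsomes from liver (Mus musculus) for pharmacokinetics, read by LC-MS, with a stated time of 10 min, tested at 1 uM; a higher number here means faster removal of the compound, a lower number slower removal. Compound 1 stands at the lowest of the three numbers, but the others sit close by: a 1.6-fold higher number from compound 1 to compound 2 (0.20 log units; within the scatter), a 1.7-fold higher number from compound 1 to compound 3 (0.23 log units; within the scatter) and a 1.1-fold higher number from compound 2 to compound 3 (0.03 log units; within the scatter) all fall within the scatter, so no ordering among the three compounds can be claimed from these values.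

Compound 4, `CN1C[C@H](C(=O)Nc2ccccc2F)[C@@H](c2ccc(/C=C/C(=O)Nc3ccccc3N)cc2)C1`, has not yet been measured in this assay. Against compound 1 the difference is 2-fluorophenyl in place of 4-fluorophenyl on an amide-type nitrogen. Among the compounds with values here, no measured step exchanges one fluorophenyl for another, so nothing bears on this change directly. The nearest information is the pair of exchanges at the same amide-type nitrogen, a 1.6-fold higher number from compound 1 to compound 2 (0.20 log units; within the scatter) and a 1.7-fold higher number from compound 1 to compound 3 (0.23 log units; within the scatter), each within the scatter; the three measured compounds give no sign that the group on this nitrogen shifts the number beyond the scatter. The step from compound 1 to compound 4 is therefore expected to be a 1.2-fold higher number from compound 1 to compound 4 (0.07 log units; within the scatter), that is, nothing beyond the scatter. Compound 4 is estimated at 40 mL/min/kg in this assay, with a range from 20 mL/min/kg to 80 mL/min/kg.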

Compound 4, clearance: 67 mL/min/kg
Compound 4: middle estimate off by 1.7-fold (0.22 log units), on the low side; measured number inside the range.
By their numbers in this assay, from the lowest: compounds 1, 2, 3 and 4 (each within the scatter of the next).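

In this assay, within the data shown here, the exchange of 4-fluorophenyl for 2-fluorophenyl on the amide-type nitrogen keeps the same atoms and alters only how they are joined, and it gives a 2.0-fold higher number from compound 1 to compound 4 (0.29 log units; within the scatter); this is the first reading of such an exchange at this position, and even this step stays within the scatter, though close to its edge. The other new steps, a 1.2-fold higher number from compound 3 to compound 4 (0.06 log units; within the scatter) and a 1.2-fold higher number from compound 2 to compound 4 (0.09 log units; within the scatter), are small, so compound 4 cannot be separated from the 3-chlorophenyl or 4-methoxyphenyl anilides, and across the four compounds no group on this nitrogen moves the number beyond the scatter. Nothing at hand gives a reason for any of these numbers.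

As far as these compounds go, whether the two fluorophenyl groups truly differ in clearance stays open, as a step within the scatter can neither confirm nor exclude a small real difference. Also open, from the compounds shown here alone, is whether anything other than a substituted phenyl at this nitrogen, such as a plain alkyl chain, an amine-bearing chain or a chain ending in a carboxylic acid, would give a step beyond the scatter.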